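The source may report more compounds than this note shows. Statements on the series, on what has been measured and on what is new or still open speak of the compounds shown alone.

Measured compounds:
- compound 1 `Cc1ccc(Nc2nc(Cl)nc3c2ncn3Cc2ccc(C(=O)Nc3ccccc3N)cc2)cc1`: 82%
- compound 2 `Nc1ccccc1NC(=O)/C=C/c1ccc(Cn2cnc3c(Nc4cccc(OC(F)(F)F)c4)nc(Cl)nc32)cc1`: 37.6%

In a functional assay on HepG2 cells (Homo sapiens) for antiproliferative activity, read by CCK-8 assay, with a stated time of 72 h, tested at 8 uM (a lower number here means a weaker effect, a higher number a stronger effect of the compound at the concentration tested), compound 2 gives 37.6%, the lower of the two numbers; compound 1 gives 82%, a gap that lies beyond the usual scatter. Compound 3 `Nc1ccccc1NC(=O)c1ccc(Cn2cnc3c(Nc4cccc(OC(F)(F)F)c4)nc(Cl)nc32)cc1` is not yet measured. It differs from compound 2 in one place: (2-aminophenyl)carbamoyl in place of 2-((2-aminophenyl)carbamoyl)ethenyl on an aromatic carbon. Compound 1 already carries the (2-aminophenyl)carbamoyl group, so an upward step is expected, though one pair is thin ground. The step from compound 2 to compound 3 is estimated at a number 27.4 percentage points higher from compound 2 to compound 3 (beyond the scatter). Compound 3 is expected to reach 65%, within 40% to 85%.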

Compound 3, a percentage reported as inhibition, at one concentration (the size of the read-out at that concentration, not a potency): 31.2%
Compound 3: middle estimate off by 33.8 percentage points, on the high side; the measured number lies below the stated range.
By their numbers in this assay, from the lowest: compounds 3 and 2 (each within the scatter of the next); then compound 1.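

In this assay, putting (2-aminophenyl)carbamoyl in place of 2-((2-aminophenyl)carbamoyl)ethenyl gives a number 6.4 percentage points lower from compound 2 to compound 3 (within the scatter), so this assay does not separate the two groups at this position. The large step lies elsewhere: 3-(trifluoromethoxy)phenyl in place of 4-methylphenyl gives a number 50.8 percentage points lower from compound 1 to compound 3 (beyond the scatter), showing that the group on the nitrogen matters in this pair. No available evidence explains either step. Still open, as far as these compounds go, is whether the ethenyl-containing group would also match (2-aminophenyl)carbamoyl alongside 4-methylphenyl. How a carboxylic acid would fare at this position is also unknown.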